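Closing the Amino Group into a Ring on the Shared Core

The source may hold more compounds than are shown below. What is called first, only, known or untested is meant among the compounds shown, and "the series" means these compounds.

Measured compounds:
Compound 1 `CN(C)c1cc(OCc2cc(F)c(Oc3ccc(Cl)c(C(F)(F)F)c3)c(F)c2)nc(=O)n1C`: 82.8 mL/min/kg
Compound 2 `CCN(CC)c1cc(OCc2cc(F)c(Oc3ccc(Cl)c(C(F)(F)F)c3)c(F)c2)nc(=O)n1C`: 41.9 mL/min/kg

In an ADME assay on S9 fraction from liver (Rattus norvegicus, strain Wistar) for metabolic stability, tested at 0.1 uM (on this read-out lower numbers stand for slow clearance and higher numbers for fast clearance), compound 1 gives 82.8 mL/min/kg, and compound 2 gives 41.9 mL/min/kg. Compound 2 has the lower of the two numbers, but the step of a 2.0-fold lower number from compound 1 to compound 2 (0.30 log units; within the scatter) lies within the scatter, so the two cannot be ordered. Compound 3 `Cn1c(N2CCCC2)cc(OCc2cc(F)c(Oc3ccc(Cl)c(C(F)(F)F)c3)c(F)c2)nc1=O` carries the change (pyrrolidin-1-yl in place of diethylamino on an aromatic carbon). For the measured compounds named here, the single measured step concerns a different change, the one from dimethylamino to diethylamino, and was a 2.0-fold lower number from compound 1 to compound 2 (0.30 log units; within the scatter); no measured step covers the closing of the two ethyl arms into a five-membered ring. The account therefore expects for compound 3 a step of about a 1.1-fold higher number from compound 2 to compound 3 (0.03 log units; within the scatter), that is, no step beyond the scatter. The expected value for compound 3 is 45 mL/min/kg, with a range from 20 mL/min/kg to 95 mL/min/kg.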

Compound 3, clearance: 3.11 mL/min/kg
Beside the measured number, compound 3's estimate is 14-fold (1.16 log units) above it; measured number outside the range, below it.
By their numbers in this assay, from the lowest: compound 3; then compounds 2 and 1 (each within the scatter of the next).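

In this assay, the amino group on this aromatic carbon turns out to matter far more than the two open-chain compounds suggested: pyrrolidin-1-yl in place of diethylamino gives a 13-fold lower number from compound 2 to compound 3 (1.13 log units; beyond the scatter) and pyrrolidin-1-yl in place of dimethylamino gives a 27-fold lower number from compound 1 to compound 3 (1.43 log units; beyond the scatter) on the same core. Dimethylamino and diethylamino could not be told apart, so changing the open-chain arms showed no step beyond the scatter. Diethylamino and pyrrolidin-1-yl have the same count of heavy atoms, so the large step comes with closing the ring and not with any change in that count.

The compounds shown leave open whether the step belongs to pyrrolidine alone or would also appear with piperidine, morpholine or azetidine at this position. They also leave open whether a substituted pyrrolidine would keep it.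

Nothing available bears on why the ring has this effect.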